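This account rests on a few compounds, and the source may have more. Where it says the series, first, only, none or still open, it means among the compounds named here.

Measured so far in an ADME assay on HeLa Rh cells (Homo sapiens) for cytotoxicity, read by microscopy; on this read-out lower numbers stand for higher toxicity in this test and higher numbers for lower toxicity in this test:
compound 1, `COc1cc(CC(O)c2ccc(-c3ccc(C#N)cc3)cc2)c([N+](=O)[O-])cc1OC`: 4700 nM
compound 2, `COc1cc(CC(O)c2ccc(-c3ccccc3F)cc2)c([N+](=O)[O-])cc1OC`: 5000 nM
compound 3, `COc1cc(CC(O)c2ccc(-c3ccccc3[N+](=O)[O-])cc2)c([N+](=O)[O-])cc1OC`: 9500 nM

Among these three, compound 1 gives the lowest number. Its nearest neighbour is compound 2, with a 1.1-fold higher number from compound 1 to compound 2 (0.03 log units; within the scatter), and its furthest is compound 3, with a 2.0-fold higher number from compound 1 to compound 3 (0.31 log units; beyond the scatter). Compound 4, `COc1cc(CC(O)c2ccc(-c3ccccc3CO)cc2)c([N+](=O)[O-])cc1OC`, differs from compound 1 in one place: 2-(hydroxymethyl)phenyl in place of 4-cyanophenyl on an aromatic carbon.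

The two steps leading away from compound 1 bear on this change, as each replaces the 4-cyanophenyl with a phenyl carrying a different substituent. One of them stayed within the scatter, the other was modest. For compound 4 a similar outcome is expected in this assay: a small step upward or none beyond the scatter, a 1.3-fold higher number from compound 1 to compound 4 (0.11 log units; within the scatter). Compound 4 is therefore estimated at 6000 nM, expected to fall between 3000 nM and 12000 nM.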

Compound 4, half-maximal cytotoxic concentration: 24000 nM
Estimate against measurement, compound 4: 4.0-fold (0.60 log units) below; the measured number lies above the stated range.
By their numbers in this assay, from the lowest: compounds 1, 2 and 3 (each within the scatter of the next, the first and the last beyond it); then compound 4.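

In this assay the 2-(hydroxymethyl)phenyl group moves the number well beyond what the earlier groups reached, with a 5.1-fold higher number from compound 1 to compound 4 (0.71 log units; beyond the scatter) and likewise a 4.8-fold higher number from compound 2 to compound 4 (0.68 log units; beyond the scatter) and a 2.5-fold higher number from compound 3 to compound 4 (0.40 log units; beyond the scatter). This position can therefore shift the read-out more than the first three compounds suggested, and the entering group, unlike the 4-cyanophenyl, counts a hydrogen-bond donor. Nothing available explains this rise. From the compounds shown here alone, whether the hydroxyl itself matters remains open: an aminomethyl group, a carboxylic acid or a longer hydroxyethyl chain on that ring could separate these possibilities.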